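The source may hold more compounds than are shown below. What is called first, only, known or untested is meant among the compounds shown, and "the series" means these compounds.

Working notes on the series.

Compound 1 is `COc1cc(-n2c(-c3ccccc3)csc2=S)cc(OC)c1OC`; in a functional assay on T47D cells (Homo sapiens) for cytotoxicity, read by MTT assay, with a stated time of 48 h (a higher number here means a weaker inhibitor, a lower number a stronger inhibitor), compound 1 gives 31.6 ug/mL. Compound 2 is `COc1cc(-n2c(-c3ccc(Cl)cc3)csc2=S)cc(OC)c1OC`, carrying chloro in place of hydrogen on an aromatic carbon. For compound 2 this assay reports only a limit, > 100 ug/mL. The measured step is therefore open-ended: an at least 3.1-fold higher number from compound 1 to compound 2 (0.50 log units; beyond the scatter), because compound 2 sits at the limit of > 100 ug/mL in this assay, at which 1 of the 2 values shown sits. Where compound 2 stands on the numbers shown is thus known only as a lower bound, not as a value.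

Compound 3 is `COc1cc(-n2c(-c3ccc(-c4ccccc4)cc3)csc2=S)cc(OC)c1OC`. The change from compound 2 is phenyl in place of chloro on an aromatic carbon, para to a large group. Within the data shown here, no measured step covers a phenyl at this position; the only step that bears on it is the hydrogen-to-chloro step above, which weakened inhibition by at least a modest amount and left compound 2 at the limit. With compound 2 already at the limit, no clear recovery is expected in this assay from compound 2 to compound 3. Compound 3 is therefore estimated at 100 ug/mL, in the range 30 ug/mL to 300 ug/mL. As a step, this estimate means a number no higher from compound 2 to compound 3 (the limit leaves the size open), with a strong chance that only a limit is reported again.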

Compound 3, half-maximal inhibitory concentration: > 100 ug/mL
Compound 3: only a limit was reported; the forecaster's own chance of this, stated with the estimate: 60%; the middle value sits exactly at the limit.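

Phenyl in place of hydrogen on this aromatic carbon, para to a large group, gives an at least 3.1-fold higher number from compound 1 to compound 3 (0.50 log units; beyond the scatter) in this assay. Chloro, with 1 heavy atom, is therefore no longer the only substituent shown to raise the number here: phenyl, with 6 heavy atoms and a six-membered aromatic ring, does so too, and among the three compounds only compound 1, with hydrogen at this position, has a value that is not a limit. The step between the chloro and phenyl compounds cannot be read, so the two substituents cannot be ranked against each other, and the size of their effects stays open: the limit of > 100 ug/mL in this assay, at which 2 of the 3 values shown sit.

The compounds shown leave open whether an amine or a carboxylic acid on this aromatic carbon would give a value rather than a limit in this assay. They also leave open whether a change on the shared core elsewhere, with hydrogen kept at this position, would move the number from the value of compound 1, 31.6 ug/mL.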